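The source may report more compounds than this note shows. Statements on the series, on what has been measured and on what is new or still open speak of the compounds shown alone.

Compound 2 `Oc1cccc(-c2cc(-c3ccc(Cl)cc3)nc(-c3ccco3)c2)c1` carries a 3-hydroxyphenyl group and a furan-2-yl group on a shared core. For the measured compounds named here, in an assay on isolated protein for inhibition of DNA topoisomerase 1 (Homo sapiens), with a stated time of 30 min, tested at 100 uM (a lower number here means a weaker effect, a higher number a stronger effect of the compound at the concentration tested), compound 2 gives 27.1%, the higher of the two numbers known so far; compound 1 `Oc1cccc(-c2cc(-c3cccc(Cl)c3)nc(-c3ccco3)c2)c1` gives 5.5%. Going by the values given here, the only measured step, a number 21.6 percentage points higher from compound 1 to compound 2 (beyond the scatter), came with a 4-chlorophenyl in place of a 3-chlorophenyl. Compound 3 `Oc1cccc(-c2cc(-c3ccco3)nc(-c3ccccc3Cl)c2)c1` differs from compound 2 by 2-chlorophenyl in place of 4-chlorophenyl on an aromatic carbon. Among the compounds with values here, no measured step covers this change, so the expectation is loose, with a decline thought more likely than a further gain. For compound 3 the estimate is 12%, between 0% and 35%, an expected step of a number 15.1 percentage points lower from compound 2 to compound 3 (beyond the scatter).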

Compound 3, a percentage reported as inhibition, at one concentration (the size of the read-out at that concentration, not a potency): 0%
Compound 3: the middle estimate sits 12 percentage points above what was measured; the measured number falls inside the stated range.
By their numbers in this assay, from the lowest: compounds 3 and 1 (each within the scatter of the next); then compound 2.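

With all three chlorine placements on this phenyl group now in hand, this assay separates only the 4-chlorophenyl: the change to 2-chlorophenyl gives a number 27.1 percentage points lower from compound 2 to compound 3 (beyond the scatter) while the change from 3-chlorophenyl to 2-chlorophenyl gives a number 5.5 percentage points lower from compound 1 to compound 3 (within the scatter) and so separates neither. At this position, next to the ring nitrogen, where the chlorine sits on the phenyl ring therefore matters. No measurement at hand explains the difference. From the compounds shown here alone, whether a 4-methoxyphenyl or a 4-aminophenyl would match or exceed the 4-chlorophenyl remains open, as does whether the preference for the 4-chlorophenyl survives replacing the furan-2-yl group.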